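A few compounds are considered here, and "the series" means these few. Any claim that something is new, unique, unknown or untested is made for them only; others in the source may bear on it.

Measured compounds, activity in an ADME assay on the whole organism with Oryza sativa as the target, tested at 0.1 uM; a higher number here means a weaker effect of the compound at the concentration tested, a lower number a stronger effect:
- compound 1, `C[C@@H](NC(=O)Nc1ccccc1F)c1ccccc1`: 97%
- compound 2, `C[C@H](NC(=O)Nc1ccccc1F)c1ccccc1`: 98%
- compound 3, `C[C@H](NC(=O)Nc1ccc(F)cc1F)c1ccccc1`: 101%

All three values sit close together. The step of a number 1 percentage points higher from compound 1 to compound 2 (within the scatter) rests on the fact that compounds 1 and 2 differ only in the configuration as drawn: the two cores are the same except in configuration, (the two compounds have the same atoms and bonds and differ only in configuration as drawn: 1 of 1 stereo elements differ; a stereocentre at a saturated chain carbon is drawn S in compound 2 and R in compound 1). The step of a number 3 percentage points higher from compound 2 to compound 3 (within the scatter) comes with the change (fluoro in place of hydrogen on an aromatic carbon).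

Compound 4, `C[C@@H](NC(=O)Nc1c(F)cccc1F)c1ccccc1`, is not yet measured. It comes from compound 1 by fluoro in place of hydrogen on an aromatic carbon. This is the same kind of change as from compound 2 to compound 3, but the place is not the same: in compound 3 the fluoro enters meta to a fluoro group and para to a large group, whereas in compound 4 it enters ortho to a large group and meta to a fluoro group.

Given that the step from compound 2 to compound 3 was within the scatter, and that compound 1, compound 2 and compound 3 all read within the scatter of one another, the expected step from compound 1 to compound 4 in this assay is a number 2 percentage points higher from compound 1 to compound 4 (within the scatter), again within the scatter. Compound 4 is therefore estimated at 99%, between 90% and 106%.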

Compound 4, a percentage reported as activity, at one concentration (the size of the read-out at that concentration, not a potency): 100%
Compound 4: the middle estimate sits 1 percentage points below what was measured; measured number inside the range.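

Fluoro in place of hydrogen gives a number 3 percentage points higher from compound 1 to compound 4 (within the scatter) in this assay, and this agrees with the earlier step for the same change: the same change on two cores in this assay, a number 3 percentage points higher (within the scatter) from compound 2 to compound 3 and a number 3 percentage points higher (within the scatter) from compound 1 to compound 4, 0 percentage points apart, within the scatter of two such steps. The two cores carrying the change are as close as cores can be, so the agreement covers only a narrow case: the fact that compounds 1 and 2 differ only in the configuration as drawn. It shows that the change stays within the scatter on both cores, including at the place in compound 4, ortho to a large group, but with neither step beyond the scatter, it shows no measurable shift being carried across and says nothing about a core that differs in more than configuration.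

The compounds shown leave open whether a methoxy group, an amine or a carboxylic acid on the aromatic ring, or a longer chain in place of the methyl group on the saturated carbon, would move the reading. Also open, from the compounds shown here alone, is whether any member of this series reads clearly apart from the others in this assay.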